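Chloro to nitro exchange on two cores

A few compounds are considered here, and "the series" means these few. Any claim that something is new, unique, unknown or untested is made for them only; others in the source may bear on it.

Measured compounds:
compound 1, `N#CCCn1nc(-c2ccc(OCc3ccc(Cl)cc3)cc2)oc1=S`, 2700 nM
compound 2, `N#CCCn1nc(-c2ccc(OCc3ccc([N+](=O)[O-])cc3)cc2)oc1=S`, 2600 nM
compound 3, `N#CCCN1N=C(c2ccc(OCc3ccc(Cl)cc3)cc2)OCC1=O`, 3400 nM

In an assay for inhibition of Amine oxidase [flavin-containing] A (Rattus norvegicus) (a higher number here means a weaker inhibitor, a lower number a stronger inhibitor), compound 1 gives 2700 nM and compound 2 gives 2600 nM. Compound 3 gives 3400 nM in this assay. All three values sit within the scatter of one another, so no order among them is read.

Compound 1 and compound 2 differ by nitro in place of chloro on an aromatic carbon. The step of a 1.0-fold lower number from compound 1 to compound 2 (0.02 log units; within the scatter). Compound 3 and compound 1 share the 4-chlorophenyl part but carry different cores; the difference between the two cores is not broken down here.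

Compound 4, `N#CCCN1N=C(c2ccc(OCc3ccc([N+](=O)[O-])cc3)cc2)OCC1=O`, is not yet measured. It differs from compound 3 by nitro in place of chloro on an aromatic carbon, the same kind of change as that from compound 1 to compound 2, with the place described in the same words in both cases. The change occurs twice among the compounds shown.

For compound 4 the step of a 1.0-fold lower number from compound 3 to compound 4 (0.01 log units; within the scatter) is expected, beside the measured step of a 1.0-fold lower number from compound 1 to compound 2 (0.02 log units; within the scatter). Going by the values given here, this rests only on the one measured example of the change, because a 1.0-fold lower number from compound 1 to compound 2 (0.02 log units; within the scatter), and on the value of compound 3, 3400 nM. Whether the change behaves the same way on the core of compound 3 as on the core of compound 1 is not known from these data, so the range is kept wide.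

Compound 4 is estimated at 3300 nM in this assay, with the likely span 1500 nM to 7500 nM.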

Compound 4, half-maximal inhibitory concentration: 2000 nM
Compound 4: the middle estimate sits 1.7-fold (0.22 log units) above what was measured; measured number inside the range.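

Read across the two cores, nitro in place of chloro on an aromatic carbon travels without a step that can be told from noise. In this assay, the new step (a 1.7-fold lower number from compound 3 to compound 4 (0.23 log units; within the scatter)) stays inside the usual scatter, so the 4-chlorophenyl to 4-nitrophenyl exchange on the core of compound 3 gives no reliable shift in the number. This does not show that the exchange is without effect on every core or that the two cores respond identically, as the series holds only two examples of the change, both in one assay and both at the same place, and small differences could lie hidden within the scatter; the two examples, set side by side, do not differ: the same change on two cores in this assay, a 1.0-fold lower number (0.02 log units; within the scatter) from compound 1 to compound 2 and a 1.7-fold lower number (0.23 log units; within the scatter) from compound 3 to compound 4, 1.6-fold (0.21 log units) apart, within the scatter of two such steps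

The compounds shown leave open whether an amine or a carboxylic acid in place of chloro on that aromatic carbon, or a longer chain in place of the chain that carries the nitrile, would move the number beyond the scatter. Also open, going by these compounds, is which part of the core of compound 1 or of compound 3 bears on the number, and whether the exchange would behave the same way on a third core.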